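Solubility across benzyl and phenoxy variants of a shared core

A few compounds are considered here, and "the series" means these few. Any claim that something is new, unique, unknown or untested is made for them only; others in the source may bear on it.

Measured compounds:
- compound 1, `Cc1cc(C)cc(Cc2ccc3c(NCCCNCc4ccco4)ccnc3c2)c1`: 4200 nM
- compound 2, `CN(C)c1cccc(Oc2ccc3c(NCCCNCc4ccco4)ccnc3c2)c1`: 14500 nM
- compound 3, `COc1ccc(Oc2ccc3c(NCCCNCc4ccco4)ccnc3c2)cc1`: 14500 nM

In a physicochemical assay for solubility, with a stated time of 18 h, at pH 7.4 (on this read-out lower numbers stand for lower solubility and higher numbers for higher solubility), compound 1 gives the lowest of the three numbers. The two measured steps away from it go the same way: a 3.5-fold higher number from compound 1 to compound 2 (0.54 log units; beyond the scatter) and a 3.5-fold higher number from compound 1 to compound 3 (0.54 log units; beyond the scatter). Between the two phenoxy compounds, no change at the digits printed from compound 2 to compound 3 (within the scatter), so compound 2 and compound 3 cannot be ordered on these data.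

Compound 4, `FC(F)(F)c1cccc(Cc2ccc3c(NCCCNCc4ccco4)ccnc3c2)c1`, is not yet measured. It differs from compound 1 as follows: 3-(trifluoromethyl)phenyl in place of 3,5-dimethylphenyl on a saturated chain carbon bound to an aromatic carbon. Among the measured compounds shown here, no measured step matches this kind of change. Both steps from compound 1 exchanged the whole 3,5-dimethylbenzyl group for a phenoxy group, whereas compound 4 keeps the saturated chain carbon bound to an aromatic carbon and alters only the aryl ring on it. The step between compound 2 and compound 3, which swaps one aryl ring for another on an unchanged linker, stayed within the scatter, and that is the closest analogy here.

For compound 4 the expectation is therefore a number close to that of compound 1, with a 1.1-fold higher number from compound 1 to compound 4 (0.03 log units; within the scatter) expected to stay within the scatter. The estimated value for compound 4 in this assay is 4500 nM, with a range from 2000 nM to 10000 nM.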

Compound 4, solubility: 4200 nM
Beside the measured number, compound 4's estimate is 1.1-fold (0.03 log units) above it, and the stated range covers the measured number.
By their numbers in this assay, from the lowest: compounds 1 and 4 (each within the scatter of the next); then compounds 2 and 3 (each within the scatter of the next).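

In this assay the aryl ring on the saturated chain carbon bound to an aromatic carbon was exchanged with no visible effect, no change at the digits printed from compound 1 to compound 4 (within the scatter) with 3-(trifluoromethyl)phenyl in place of 3,5-dimethylphenyl. Among the compounds shown here, the earlier steps from compound 1 replaced the whole 3,5-dimethylbenzyl group with a phenoxy group, so this is the first reading of a change to the ring alone while that saturated carbon stays in place, and the entering group, with 10 heavy atoms including 3 fluorine, replaces one of 8 carbon atoms without moving the number beyond the scatter. No measurement given here explains this result.

Open still is whether a ring on this carbon carrying an amine or a carboxylic acid would stay as close to compound 1 as compound 4 does, since both rings seen at this position carry only carbon or fluorine substituents. Also open, on these data alone, is how much of the difference between compound 1 and the phenoxy compounds belongs to the oxygen itself, as compound 2 and compound 3 differ from compound 1 in both the linking atom and the ring.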